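Ring size at the amine position: compound 3 to compound 4

The compounds below may be only part of what the source reports. "The series", "measured", "known", "first", "only" and "open" are said of these compounds alone.

Measured compounds:
- compound 1 `C/C=C/C(=O)Nc1cc2c(N3CCCc4ccccc43)ncnc2cc1O[C@@H]1CCOC1`: 9350 nM
- compound 2 `CCC/C=C/C(=O)Nc1cc2c(N3CCCc4ccccc43)ncnc2cc1O[C@@H]1CCOC1`: 11800 nM
- compound 3 `CCN(CC)C/C=C/C(=O)Nc1cc2c(N3CCc4ccccc43)ncnc2cc1O[C@@H]1CCOC1`: 5780 nM

All three were run in a functional assay on PC-3 cells (Homo sapiens) for antiproliferative activity, read by MTT assay, with a stated time of 72 h; on this read-out lower numbers stand for stronger inhibition and higher numbers for weaker inhibition. Compound 3 gives the lowest number of the three; against compound 1 the gap is within the scatter, against compound 2 it is beyond it, so compound 3 cannot be called the strongest of the set on these numbers alone.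

Compound 4 `CCN(CC)C/C=C/C(=O)Nc1cc2c(N3CCCc4ccccc43)ncnc2cc1O[C@@H]1CCOC1` differs from compound 3 in one place: 1,2,3,4-tetrahydroquinolin-1-yl in place of 2,3-dihydro-1H-indol-1-yl on an aromatic carbon. For the measured compounds named here, no measured pair isolates this ring change. Going by the values given here, the only single-point step in the set, a 1.3-fold higher number from compound 1 to compound 2 (0.10 log units; within the scatter), concerns the amide side chain and not the ring, and it stays within the scatter. Compounds 1 and 2 carry the ring that enters here, but their side chains differ from that of compound 3, so they give only a rough frame; their numbers sit within the scatter of compound 3 or just beyond it.

On this basis no step beyond the scatter is expected for compound 4 in this assay, and a 1.1-fold higher number from compound 3 to compound 4 (0.05 log units; within the scatter) is the estimated change. Compound 4 is therefore expected near 6500 nM, with a range from 2500 nM to 17000 nM.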

Compound 4, half-maximal inhibitory concentration: 4270 nM
Compound 4: the middle estimate sits 1.5-fold (0.18 log units) above what was measured; the range from low to high includes it.
By their numbers in this assay, from the lowest: compounds 4, 3, 1 and 2 (each within the scatter of the next, the first and the last beyond it).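

In this assay, the change from 2,3-dihydro-1H-indol-1-yl to 1,2,3,4-tetrahydroquinolin-1-yl on this aromatic carbon can now be read directly: it gives a 1.4-fold lower number from compound 3 to compound 4 (0.13 log units; within the scatter), so with the diethylamino side chain held fixed, the two rings cannot be told apart in this assay. With 1,2,3,4-tetrahydroquinolin-1-yl held fixed, the side chain registers where the ring does not: diethylamino on the saturated chain carbon gives a 2.2-fold lower number from compound 1 to compound 4 (0.34 log units; beyond the scatter) and, in place of ethyl, a 2.8-fold lower number from compound 2 to compound 4 (0.44 log units; beyond the scatter), both modest steps. Nothing available here bears on the reason for any of these steps.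

For the compounds shown here, it remains open whether the ring change would stay this small with a side chain other than diethylamino, since the only direct comparison of the two rings carries that one group. From the compounds shown here alone, it also remains open whether a morpholine, a piperidine or a dimethylamino group on the same saturated chain carbon would match diethylamino or move the number further in this assay.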